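The source may report more compounds than this note shows. Statements on the series, on what has been measured and on what is new or still open speak of the compounds shown alone.

Measured compounds in this series:

compound 1 `CC#CCOC(=O)/C=C(C)/C=C/CC(C)CCCC(C)C` gives 6.4 in a physicochemical assay for lipophilicity; on this read-out lower numbers stand for lower lipophilicity and higher numbers for higher lipophilicity
compound 2 `C=CCOC(=O)/C=C(C)/C=C/CC(C)CCCC(C)C` gives 6.73 in this assay
compound 3 `C=CCOC(=O)/C=C(C)/C=C/CC(C)CCCC(C)(C)OC` gives 5.53 in this assay

Compound 3 is the lowest of the three numbers; compound 1 is the nearest and compound 2 the furthest, both beyond the scatter.

Compound 4 `COC(C)(C)CCCC(C)C/C=C/C(C)=C/C(=O)CC(C)C` is not yet measured. Its change from compound 3: isobutyl in place of allyloxy on a carbonyl carbon. The group that leaves carries one hydrogen-bond acceptor, the group that enters carries none.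

Neither measured step touches this place. The step of a number 0.33 log units higher from compound 1 to compound 2 (beyond the scatter) concerns the chain carbon bound to the ester oxygen, and the step of a number 1.20 log units lower from compound 2 to compound 3 (beyond the scatter) concerns the far end of the chain. Within the data shown here, no measured step exchanges an oxygen-bearing group for an all-carbon group on the carbonyl carbon, so the expectation for compound 4 rests on the change itself. A modest upward step is expected, a number 0.47 log units higher from compound 3 to compound 4 (beyond the scatter), with compound 4 estimated at 6, ranging from 5.5 to 6.6.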

Compound 4, partition coefficient: 6.02
For compound 4 the middle estimate is 0.02 log units below the measured one; the range from low to high includes it.
By their numbers in this assay, from the lowest: compound 3; then compound 4; then compound 1; then compound 2.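

In this assay, among these compounds, isobutyl in place of allyloxy on a carbonyl carbon gives a number 0.49 log units higher from compound 3 to compound 4 (beyond the scatter), the first reading at this position, since the earlier steps concerned other places in the chain. The series now shows that this carbonyl substituent can be exchanged with a change beyond the scatter, while the number of heavy atoms stays the same and the hydrogen-bond acceptor of the leaving group and its double bond are both lost. No supporting data bear on the origin of this step.

The compounds shown leave open how the step divides between the loss of the oxygen and the loss of the double bond, as both go in the same exchange. Also open, from the compounds shown here alone, is where a propoxy group or an amine on the same carbonyl carbon would fall in this assay.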